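Difluoromethoxy to cyano: clearance notes on the series

The source may report more compounds than this note shows. Statements on the series, on what has been measured and on what is new or still open speak of the compounds shown alone.

In an ADME assay on microsomes from liver (Homo sapiens) for metabolic stability, with a stated time of 60 min, tested at 1 mg/mL (on this read-out lower numbers stand for slow clearance and higher numbers for fast clearance), compound 2 `COc1nc2ccc(Br)cc2cc1[C@@H](c1ccnc(OC)c1OC)[C@@](O)(CCN(C)C)c1cccc(OC(F)F)c1` gives 11 mL.min-1.g-1 and sits within the scatter of compound 1 `COc1nc2ccc(Br)cc2cc1[C@@H](c1ccnc(OC)c1OC)[C@@](O)(CCN(C)C)c1cccc(C)c1` at 13 mL.min-1.g-1 on this read-out. The change to compound 3 `COc1nc2ccc(Br)cc2cc1[C@@H](c1ccnc(OC)c1OC)[C@@](O)(CCN(C)C)c1cccc(C#N)c1` is cyano in place of difluoromethoxy on an aromatic carbon and puts cyano in place of difluoromethoxy on an aromatic carbon. Going by the values given here, the only measured step bearing on this, a 1.2-fold lower number from compound 1 to compound 2 (0.07 log units; within the scatter) for difluoromethoxy in place of methyl, lies within the scatter, so no step beyond the scatter is expected in this assay here. The expected step is no change at the digits printed from compound 2 to compound 3 (within the scatter) and no more than that. Compound 3 is estimated at 11 mL.min-1.g-1 with 6 mL.min-1.g-1 to 20 mL.min-1.g-1 as the expected range.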

Compound 3, intrinsic clearance in microsomes: 19 mL.min-1.g-1
Beside the measured number, compound 3's estimate is 1.7-fold (0.24 log units) below it; the range from low to high includes it.
By their numbers in this assay, from the lowest: compounds 2, 1 and 3 (each within the scatter of the next).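

In this assay the position now holds methyl, difluoromethoxy and cyano, and the nitrile stays within the scatter of both other groups, with a 1.7-fold higher number from compound 2 to compound 3 (0.24 log units; within the scatter) and a 1.5-fold higher number from compound 1 to compound 3 (0.16 log units; within the scatter). Going from difluoromethoxy to cyano, and so from 4 heavy atoms to 2, therefore separates no compound on this read-out. Nothing available bears on the cause of these numbers. Still open, going by these compounds, is whether an amine or a carboxylic acid at this position would give a step beyond the scatter.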